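A Second Long Chain on the Other Side of Compound 2

The compounds below may be only part of what the source reports. "The series", "measured", "known", "first", "only" and "open" are said of these compounds alone.

For the measured compounds named here, in a functional assay on MCF7 cells (Homo sapiens) for inhibition, read by MTT assay, with a stated time of 72 h (a lower number here means a stronger inhibitor of growth, a higher number a weaker inhibitor of growth), compound 2 `CC(C)=CCC/C(C)=C/C(=O)NC(=N)NC(=O)C=C(C)C` gives 41500 nM, which stands as the lower of the two numbers measured so far, although compound 1 `CC(C)=CC(=O)NC(=N)NC(=O)C=C(C)C` gives 59700 nM and the two cannot be told apart within the scatter. Compound 3 `CC(C)=CCC/C(C)=C/CC/C(C)=C/C(=O)NC(=N)NC(=O)/C=C(\C)CCC=C(C)C` differs from compound 2 by 3,7-dimethylocta-2,6-dien-1-yl in place of hydrogen on a saturated chain carbon bound to a double-bonded chain carbon. Going by the values given here, the only step that bears on this is a 1.4-fold lower number from compound 1 to compound 2 (0.16 log units; within the scatter), itself within the scatter. Only a small gain beyond that is expected, and the estimated step is a 1.7-fold lower number from compound 2 to compound 3 (0.22 log units; within the scatter). Compound 3 is therefore estimated at 25000 nM, with a likely range from 10000 nM to 60000 nM.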

Compound 3, concentration for 50% growth inhibition: 51200 nM
For compound 3 the middle estimate is 2.0-fold (0.31 log units) below the measured one; the measured number falls inside the stated range.
By their numbers in this assay, from the lowest: compounds 2, 3 and 1 (each within the scatter of the next).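

In this assay, putting 3,7-dimethylocta-2,6-dien-1-yl on this saturated chain carbon gives a 1.2-fold higher number from compound 2 to compound 3 (0.09 log units; within the scatter), so even this chain of 10 heavy atoms leaves the number within the scatter. Together with the earlier step, which added the 3-methylbut-2-en-1-yl group, this shows two different chains at this kind of position without a readable change. No measurement at hand accounts for this result. Still open, from the compounds shown here alone, is whether a group of another kind here, such as an amine or a carboxylic acid, would move the number beyond the scatter.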